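The source may report more compounds than this note shows. Statements on the series, on what has been measured and on what is new or still open speak of the compounds shown alone.

Compound 1 `CCCCCCCCOC(=O)c1cc(O)c(O)c(O)c1` and compound 2 `CCCCCCCCCCCCCCOC(=O)c1cc(O)c(O)c(O)c1` share one core and differ only in the ester chain. Among the measured compounds shown here, in a functional assay on L1210 cells (Mus musculus) for cytotoxicity (a lower number here means a stronger inhibitor, a higher number a weaker inhibitor), compound 1 gives 22000 nM, while compound 2 gives 8500 nM, the lowest of the two numbers measured so far; that step, a 2.6-fold lower number from compound 1 to compound 2 (0.41 log units; beyond the scatter), came with hexyl in place of hydrogen on the chain. Compound 3 `CCCCCCCCCCOC(=O)c1cc(O)c(O)c(O)c1` carries hydrogen in place of butyl on a saturated chain carbon, ten or more bonds along the chain from an oxygen next to a carbonyl group. For the measured compounds named here, this shortens the chain partway back toward compound 1, so the single step that bears on it, a 2.6-fold lower number from compound 1 to compound 2 (0.41 log units; beyond the scatter), points to a modest rise in the number. Compound 3 is expected near 16000 nM, between 8000 nM and 32000 nM, as a 1.9-fold higher number from compound 2 to compound 3 (0.27 log units; within the scatter) in this assay.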

Compound 3, half-maximal inhibitory concentration: 12200 nM
The estimate for compound 3 lay 1.3-fold (0.12 log units) above the measured number, within the range that was stated.
By their numbers in this assay, from the lowest: compounds 2, 3 and 1 (each within the scatter of the next, the first and the last beyond it).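

In this assay, hydrogen in place of butyl gives (a 1.4-fold higher number from compound 2 to compound 3 (0.16 log units; within the scatter)), and ethyl in place of hydrogen on the chain of compound 1 gives (a 1.8-fold lower number from compound 1 to compound 3 (0.26 log units; within the scatter)). Both steps lie within the scatter, so compound 3 cannot be told apart from either compound 1 or compound 2, although those two differ beyond the scatter. Across these three compounds, the chain length that was changed therefore has only a gradual effect on the number. No measurement here explains this trend. Still open, on these data alone, is whether a longer chain than that of compound 2 continues the trend, and whether an amide in place of the ester keeps the cytotoxicity.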